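The source may hold more compounds than are shown below. What is called first, only, known or untested is meant among the compounds shown, and "the series" means these compounds.

In a functional assay on A549 cells (Homo sapiens) for inhibition, read by MTT assay, with a stated time of 72 h (on this read-out lower numbers stand for stronger inhibition and higher numbers for weaker inhibition), compound 1, with the structure `Cc1ccc(CN2CCc3ncn(COCc4ccccc4)c3/C(=C/c3ccccc3)C2=O)cc1`, gives 11400 nM. Two close relatives share its core and differ only in the group carried on the saturated chain carbon bound to the amide-type nitrogen in the ring. Compound 2, `Cc1cc(C)cc(CN2CCc3ncn(COCc4ccccc4)c3/C(=C/c3ccccc3)C2=O)c1`, gives 22500 nM in this assay. Compound 3, `COc1ccc(CN2CCc3ncn(COCc4ccccc4)c3/C(=C/c3ccccc3)C2=O)cc1`, gives 46800 nM in this assay. The step of a 2.0-fold higher number from compound 1 to compound 2 (0.30 log units; within the scatter) lies within the scatter, so compound 1 and compound 2 cannot be told apart, while a 4.1-fold higher number from compound 1 to compound 3 (0.61 log units; beyond the scatter) is a modest but real rise, and a 2.1-fold higher number from compound 2 to compound 3 (0.32 log units; beyond the scatter) points the same way.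

Compound 4, `O=C1/C(=C\c2ccccc2)c2c(ncn2COCc2ccccc2)CCN1Cc1ccc2ccccc2c1`, has not yet been measured. Its difference from compound 1 is naphthalen-2-yl in place of 4-methylphenyl on a saturated chain carbon bound to an amide-type nitrogen in a ring. Within the data shown here, none of the measured steps swaps in a second fused aromatic ring; the closest guide is the exchange of one substituted phenyl for another from compound 1 to compound 2, which stayed within the scatter, and the methoxy exchange from compound 1 to compound 3, which cost a modest amount. A ring-for-ring swap keeping carbon-only aromatics therefore seems unlikely to move the number far in either direction.

Compound 4 is expected to give 9000 nM in this assay, within a range of 3000 nM to 30000 nM. This estimate corresponds to an expected step of a 1.3-fold lower number from compound 1 to compound 4 (0.10 log units; within the scatter).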

Compound 4, half-maximal inhibitory concentration: 26400 nM
For compound 4 the middle estimate is 2.9-fold (0.47 log units) below the measured one; the measured number falls inside the stated range.
By their numbers in this assay, from the lowest: compounds 1, 2, 4 and 3 (each within the scatter of the next, the first and the last beyond it).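

In this assay, the step of a 2.3-fold higher number from compound 1 to compound 4 (0.36 log units; beyond the scatter) shows that an exchange involving only carbon aromatic rings can still produce a real change at this position, the saturated chain carbon bound to the amide-type nitrogen in the ring. Among these compounds, until now, the only steps beyond the scatter led to compound 3, which carries a methoxy group, while this result shows that going from 4-methylphenyl to the larger naphthalen-2-yl, with its second six-membered aromatic ring, gives no gain in this assay. Compound 4 cannot be told apart from compound 2 (a 1.2-fold higher number from compound 2 to compound 4 (0.07 log units; within the scatter)) or from compound 3 (a 1.8-fold lower number from compound 3 to compound 4 (0.25 log units; within the scatter)), and nothing shown here explains these differences.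

On these data alone, all four compounds carry an aromatic carbon ring with only methyl, methoxy or a fused ring as its variation, so it remains open how this position would respond to a pyridine ring, an amine or a carboxylic acid. As far as these compounds go, it is also open whether a plain benzyl group or a longer chain between the ring nitrogen and the aromatic ring would shift the number in either direction.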